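A few compounds are considered here, and "the series" means these few. Any claim that something is new, unique, unknown or untested is made for them only; others in the source may bear on it.

Compound 1 `CCCS(=O)(=O)Nc1ccc(F)c(C(=O)c2n[nH]c3ncc(-c4cccc(N(C)C)c4)cc23)c1F` gives 26% in an assay for binding affinity to dual specificity mitogen-activated protein kinase kinase 4 (Homo sapiens), read by KINOMEscan, tested at 100 nM; a lower number here means a stronger effect, a higher number a weaker effect of the compound at the concentration tested.
Compound 2 `CCCS(=O)(=O)Nc1ccc(F)c(C(=O)c2n[nH]c3ncc(-c4ccc(C(C)C)cc4)cc23)c1F` gives 17% in this assay.
Compound 3 `CCCS(=O)(=O)Nc1ccc(F)c(C(=O)c2n[nH]c3ncc(-c4ccc(S(C)(=O)=O)cc4)cc23)c1F` gives 1.5% in this assay.

The three compounds share one core and differ only in the aryl group attached to it. Compound 3 stands lowest of the three numbers in this assay, which means the strongest effect at this concentration: compound 2 is its nearest neighbour, with a number 15.5 percentage points lower from compound 2 to compound 3 (beyond the scatter), and compound 1 is furthest, with a number 24.5 percentage points lower from compound 1 to compound 3 (beyond the scatter). The step from compound 1 to compound 2, a number 9 percentage points lower from compound 1 to compound 2 (within the scatter), does not count as a real difference.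

Compound 4 `CCCS(=O)(=O)Nc1ccc(F)c(C(=O)c2n[nH]c3ncc(-c4ccc(-c5nnn[nH]5)cc4)cc23)c1F` has not yet been measured. It keeps everything of compound 3 except one group: 1H-tetrazol-5-yl in place of methylsulfonyl on an aromatic carbon. Cut one bond further out, the change reads 4-(methylsulfonyl)phenyl to 4-(1H-tetrazol-5-yl)phenyl. The measured steps that bear on this position are those into compound 3, a number 15.5 percentage points lower from compound 2 to compound 3 (beyond the scatter) and a number 24.5 percentage points lower from compound 1 to compound 3 (beyond the scatter), both modest and both downward when methylsulfonyl arrives. For the measured compounds named here, no measured pair shows what exchanging methylsulfonyl for a tetrazole does, so the direction is open. Because compound 3 already sits at 1.5% there is little room beneath it, and the expected step in this assay is a number 6.5 percentage points higher from compound 3 to compound 4 (within the scatter), within the scatter. Compound 4 is therefore estimated at 8%, with a range from 1% to 30%.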

Compound 4, a percentage reported as activity, at one concentration (the size of the read-out at that concentration, not a potency): 0.15%
Compound 4: middle estimate off by 7.9 percentage points, on the high side; measured number below the stated range.
By their numbers in this assay, from the lowest: compounds 4 and 3 (each within the scatter of the next); then compounds 2 and 1 (each within the scatter of the next).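

In this assay, 1H-tetrazol-5-yl can replace methylsulfonyl at this position with no readable change: the step is a number 1.4 percentage points lower from compound 3 to compound 4 (within the scatter). The new group also keeps the separation from the two other aryl groups, with a number 16.9 percentage points lower from compound 2 to compound 4 (beyond the scatter) and a number 25.9 percentage points lower from compound 1 to compound 4 (beyond the scatter), so among these compounds the low number is not tied to methylsulfonyl alone, and a group with a five-membered aromatic ring and a hydrogen-bond donor serves as well as one with no ring and no donor. Nothing measured here explains why these two different groups give such similar results.

As far as these compounds go, with both numbers this close to the bottom of a read-out taken at one concentration, any real difference in potency between compound 3 and compound 4 remains open. Also open, from the compounds shown here alone, is whether a carboxylic acid, a primary amide or an amine at the same place on the phenyl ring would match these two groups, or would instead fall back toward the numbers of compound 1 and compound 2.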